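Hydroxamic acid series: methoxy added on the fused aryl ketone

A few compounds are considered here, and "the series" means these few. Any claim that something is new, unique, unknown or untested is made for them only; others in the source may bear on it.

Of the compounds shown here, two have been measured in an assay on isolated protein for inhibition of histone deacetylase 4 (Homo sapiens), read by fluorescence; on this read-out lower numbers stand for stronger inhibition and higher numbers for weaker inhibition. Compound 1 `O=C(/C=C/c1ccc(/C=C/C(=O)c2ccc3ccccc3c2)o1)NO` gives 4380 nM in this assay, the lower of the two numbers. Compound 2 `O=C(/C=C/c1ccc(/C=C/C(=O)c2cccc(Cl)c2)o1)NO` gives 12900 nM in this assay, a higher number than that of compound 1 and beyond the usual scatter; the two differ in the aryl ketone part, so this comparison does not isolate a single change.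

Compound 3 `COc1ccc2cc(C(=O)/C=C/c3ccc(/C=C/C(=O)NO)o3)ccc2c1` is not yet measured. It differs from compound 1 by methoxy in place of hydrogen on an aromatic carbon. Within the data shown here, no measured pair shows the effect of such a substitution, so nothing here indicates the direction of the step; with the remainder of the molecule kept unchanged, the expectation is a step from compound 1 to compound 3 that stays within the usual scatter of this assay, a 1.1-fold lower number from compound 1 to compound 3 (0.04 log units; within the scatter). For compound 3 the estimated value in this assay is therefore 4000 nM, with the expected range 1500 nM to 12000 nM.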

Compound 3, half-maximal inhibitory concentration: 4040 nM
Beside the measured number, compound 3's estimate is 1.0-fold (0.00 log units) below it; measured number inside the range.
By their numbers in this assay, from the lowest: compounds 3 and 1 (each within the scatter of the next); then compound 2.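

In this assay, among these compounds, methoxy in place of hydrogen on an aromatic carbon of the fused system of two rings gives a 1.1-fold lower number from compound 1 to compound 3 (0.04 log units; within the scatter), the first comparison that isolates a single change. This position therefore tolerates methoxy, with its 2 heavy atoms and 1 hydrogen-bond acceptor, without a step beyond the scatter, and compound 1 and compound 3 cannot be told apart on this read-out. No available data bear on why the number holds at this position.

One substituent at one position leaves open whether an amine, a carboxylic acid or a longer alkoxy chain on the same aromatic carbon would also stay within the scatter of compound 1. Also open, as far as these compounds go, is whether methoxy would give a similar step on other aromatic carbons of the fused system, or on the chloro-substituted aryl ketone of compound 2.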